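Working notes: 2-ethoxyphenyl in place of 4-ethylphenyl

The source may hold more compounds than are shown below. What is called first, only, known or untested is meant among the compounds shown, and "the series" means these compounds.

Among the compounds with values here, only two members have numbers so far, both from a functional assay on ECa-109 cells for inhibition, with ECa-109 cell line (Homo sapiens) as the target, read by sulforhodamine B assay; on this read-out lower numbers stand for stronger inhibition and higher numbers for weaker inhibition. Compound 1 (`O=C1C(Nc2ccc(I)cc2)=CC(=O)c2c1nc1n2[C@H]2OC[C@@H](O)[C@H]2OC1`) gives 2530 nM. Compound 2 (`CCc1ccc(NC2=CC(=O)c3nc4n(c3C2=O)[C@H]2OC[C@@H](O)[C@H]2OC4)cc1`) gives 3080 nM. These two values lie within the scatter of each other, so compound 2 cannot be separated from compound 1 on the numbers available.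

The next compound is compound 3 (`CCOc1ccccc1NC1=CC(=O)c2nc3n(c2C1=O)[C@H]1OC[C@@H](O)[C@H]1OC3`), which keeps the shared core of compound 2 and changes one group, with 2-ethoxyphenyl in place of 4-ethylphenyl on an amine nitrogen.

Within the data shown here, the data hold no measured single-place step to serve as a guide, so neither the size nor the direction of this change can be read from the series. The working expectation is therefore no shift beyond the scatter in this assay, anchored on compound 2 at 3080 nM. The estimated step is a 1.0-fold lower number from compound 2 to compound 3 (0.01 log units; within the scatter), with no direction expected to stand out. For compound 3 the expected value is 3000 nM, with an estimated range of 1000 nM to 9000 nM.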

Compound 3, half-maximal inhibitory concentration: 4630 nM
Beside the measured number, compound 3's estimate is 1.5-fold (0.19 log units) below it, within the range that was stated.
By their numbers in this assay, from the lowest: compounds 1, 2 and 3 (each within the scatter of the next).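

Within the data shown here, the exchange at this amine nitrogen gives a 1.5-fold higher number from compound 2 to compound 3 (0.18 log units; within the scatter) in this assay and is the first measured single-place step. 2-Ethoxyphenyl, with its one extra heavy atom, an oxygen that adds a hydrogen-bond acceptor, can therefore stand in for 4-ethylphenyl here without the two compounds separating on the numbers. Nothing available bears on why the read-out stays within the scatter, and this one step cannot apportion the outcome among the differences between the two groups.

From the compounds shown here alone, it remains open whether any group on this nitrogen can move the number beyond the scatter, since one step between two substituted phenyl groups gives no guide to a cyclohexyl group, a pyridine ring or a phenyl ring carrying a carboxylic acid. The shared core is the same in compounds 1, 2 and 3, so these compounds also leave open how any change to the core would read in this assay on this series.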